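Three Cytotoxicity Limits, and a Fourth Compound to Place

The source may hold more compounds than are shown below. What is called first, only, known or untested is meant among the compounds shown, and "the series" means these compounds.

Compound 1, `CC(C)N(Cc1cccc(OCCCCCC(=O)O)c1)C(=O)c1ccc(-c2cccc(-c3ccccc3)c2)cc1`, in an ADME assay on BJ cells (Homo sapiens) for cytotoxicity, read by CellTiter-Glo and resazurin assay, with a stated time of 72 h (a higher number here means that more compound is needed for the effect, a lower number that less compound is needed), gives > 26000 nM, a limit of the assay.
Compound 2, `CCOC(=O)CCCCCOc1cccc(CN(C(=O)c2ccc(-c3cccc(N(C)C)c3)cc2)C(C)C)c1`, gives > 26000 nM, again a limit.
Compound 3, `CCOC(=O)CCCCCOc1cccc(CN(C(=O)c2ccc(-c3cccc(NC(C)=O)c3)cc2)C(C)C)c1`, gives > 26000 nM, also a limit.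

Compound 3 therefore stands only at a limit, and so do the other two values, (the limit of > 26000 nM in this assay, at which 3 of the 3 values shown sit). Among the compounds with values here, the one step between measured neighbours, from compound 2 to compound 3, is a step that the two limits leave unreadable from compound 2 to compound 3, so its size cannot be read.

Compound 4, `CCOC(=O)CCCCCOc1cccc(CN(C(=O)c2ccc(-c3cccc(-c4ccccc4)c3)cc2)C(C)C)c1`, differs from compound 3 by phenyl in place of acetamido on an aromatic carbon. Within the data shown here, no measured step bears readably on this change. Compound 1 carries the same phenyl group and sits at the limit, which points the same way. Compound 4 is expected to stay at the limit as well, a step that the limit leaves unreadable from compound 3 to compound 4 that would not be readable; the estimate is 30000 nM, within 15000 nM to 100000 nM.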

Compound 4, half-maximal effective concentration: > 26000 nM
Compound 4 gave a limit, no number; the forecaster's own chance of this, stated with the estimate: 85%; the middle value does not contradict the limit.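

The steps from compound 1, compound 2 and compound 3 to compound 4 cannot be read, since all four compounds give a limit rather than a number: the limit of > 26000 nM in this assay, at which 4 of the 4 values shown sit.

The compounds shown leave open what concentration of any of them would produce the effect in this assay, and whether their differing groups change it.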